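A few compounds are considered here, and "the series" means these few. Any claim that something is new, unique, unknown or untested is made for them only; others in the source may bear on it.

Compound 1 `OC[C@@H]1C[C@H](CO)[C@@H]2C(c3ccccc3Cl)=NO[C@H]12` and compound 2 `OC[C@@H]1C[C@H](CO)[C@@H]2C(c3ccc(Cl)cc3)=NO[C@H]12` share one core and each carry a chloro on the aromatic ring. In a functional assay on HT-29 cells (Homo sapiens) for cytotoxicity, read by MTT assay, with a stated time of 48 h (on this read-out higher numbers stand for weaker inhibition and lower numbers for stronger inhibition), compound 1 gives 33.8 ug/mL, while compound 2 gives 22.9 ug/mL; compound 2 holds the smaller of the two numbers, yet the gap to compound 1 lies within the usual scatter, so the two are not separated. Compound 3 `Cc1ccc(C2=NO[C@@H]3[C@H](CO)C[C@H](CO)[C@H]23)cc1` differs from compound 2 by one change, (methyl in place of chloro on an aromatic carbon). For the measured compounds named here, no measured pair shows what this exchange does here. Compound 3 is expected to give about 25 ug/mL, within a range from 12 ug/mL to 55 ug/mL. That expectation amounts to a 1.1-fold higher number from compound 2 to compound 3 (0.04 log units; within the scatter), a step expected to stay within the scatter.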

Compound 3, half-maximal inhibitory concentration: > 50 ug/mL
Compound 3 ended at the assay's limit; the forecaster's own chance of this, stated with the estimate: 5%; middle value at least 2.0-fold (0.30 log units) away from the limit.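

At this position, para to a large group, the two groups are not interchangeable: methyl in place of chloro gives an at least 2.1-fold higher number from compound 2 to compound 3 (0.33 log units; beyond the scatter) in this assay. The value for compound 3 is a limit, so this step gives only a lower bound and its full size stays unknown: the limit of > 50 ug/mL in this assay, at which 1 of the 3 values shown sits.

Among the compounds shown, chloro is the only group at this position that yields a number rather than a limit. From the compounds shown here alone, how a fluoro, a methoxy or an amine on the same carbon would read in this assay remains open.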